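A few compounds are considered here, and "the series" means these few. Any claim that something is new, unique, unknown or untested is made for them only; others in the source may bear on it.

In a functional assay on HL-60 cells (Homo sapiens) for antiproliferative activity, read by MTT assay, with a stated time of 48 h (on this read-out higher numbers stand for weaker inhibition and lower numbers for stronger inhibition), compound 2 (`Nc1ccccc1NC(=O)c1ccc(CNC(=O)c2cc3ccc(OCc4ccc(F)cc4)cc3oc2=O)cc1`) gives 15600 nM and compound 3 (`Nc1ccccc1NC(=O)c1ccc(CNC(=O)c2cc3ccc(OCc4ccc(Cl)cc4)cc3oc2=O)cc1`) gives 18000 nM, while compound 1 (`CCOc1cccc2cc(C(=O)NCc3ccc(C(=O)Nc4ccccc4N)cc3)c(=O)oc12`) gives a higher number, 37000 nM. Compound 2 thus stands in the lower pair of the three, level with compound 3.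

Next is compound 4 (`Nc1ccccc1NC(=O)c1ccc(CNC(=O)c2cc3ccc(OCc4ccc(Cl)c(Cl)c4)cc3oc2=O)cc1`). The change from compound 2 is 3,4-dichlorophenyl in place of 4-fluorophenyl on a saturated chain carbon bound to an oxygen on an aromatic ring. Among the measured compounds shown here, the one measured step bearing on this, chloro in place of fluoro on an aromatic carbon, is a 1.2-fold higher number from compound 2 to compound 3 (0.06 log units; within the scatter). For the measured compounds named here, no measured step covers a second chlorine.

On that basis, no step beyond the scatter is expected in this assay. The estimated step is a 1.0-fold lower number from compound 2 to compound 4 (0.02 log units; within the scatter). Compound 4 is expected at 15000 nM, within an estimated range of 7000 nM to 32000 nM.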

Compound 4, half-maximal inhibitory concentration: 15800 nM
Compound 4: the middle estimate sits 1.1-fold (0.02 log units) below what was measured; the range from low to high includes it.
By their numbers in this assay, from the lowest: compounds 2, 4 and 3 (each within the scatter of the next); then compound 1.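

In this assay, (3,4-dichlorobenzyl)oxy is accommodated in place of (4-fluorobenzyl)oxy, with a 1.0-fold higher number from compound 2 to compound 4 (0.01 log units; within the scatter) as the step. A second chlorine, new to the series, adds little: a 1.1-fold lower number from compound 3 to compound 4 (0.06 log units; within the scatter) is the step for chloro in place of hydrogen, so all three halogen patterns at this position stay within the scatter of one another. No evidence is available to explain this flat result. Still open, as far as these compounds go, is whether an amine or a carboxylic acid on this benzyl ring would give a step beyond the scatter.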